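Moving a Chlorine Around a Phenyl Ring on a Pyridine Core

A few compounds are considered here, and "the series" means these few. Any claim that something is new, unique, unknown or untested is made for them only; others in the source may bear on it.

Three compounds share one core and differ in two side groups. Compound 1 `Oc1ccc(-c2cc(-c3cccs3)nc(-c3ccccc3Cl)c2)cc1`, compound 2 `Oc1ccc(-c2cc(-c3ccc(Cl)cc3)nc(-c3cccs3)c2)cc1` and compound 3 `Oc1ccc(-c2cc(-c3ccc(Cl)cc3)nc(-c3ccsc3)c2)cc1` were tested in an ADME assay on HEK293 cells (Homo sapiens) for cytotoxicity, read by CCK-8 assay and cell counting, with a stated time of 2 days; on this read-out higher numbers stand for weaker inhibition and lower numbers for stronger inhibition. There compound 1 gives 5220 nM, compound 2 gives 4520 nM and compound 3 gives 4860 nM. One change is 2-chlorophenyl in place of 4-chlorophenyl on an aromatic carbon; the matching step is a 1.2-fold higher number from compound 2 to compound 1 (0.06 log units; within the scatter). The cores of compound 2 and compound 3 differ by thiophen-3-yl in place of thiophen-2-yl on an aromatic carbon, with the step of a 1.1-fold higher number from compound 2 to compound 3 (0.03 log units; within the scatter).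

Compound 4 `Oc1ccc(-c2cc(-c3ccsc3)nc(-c3ccccc3Cl)c2)cc1` has not been measured. It differs from compound 3 by 2-chlorophenyl in place of 4-chlorophenyl on an aromatic carbon. For the measured compounds named here, this is the same kind of change as the one from compound 2 to compound 1, not the same: there the changed position was meta to a thiophen-2-yl group, here it is meta to a thiophen-3-yl group. Because a 1.2-fold higher number from compound 2 to compound 1 (0.06 log units; within the scatter) stayed within the scatter, the step from compound 3 to compound 4 is expected to be small, about a 1.2-fold higher number from compound 3 to compound 4 (0.06 log units; within the scatter). Compound 4 is therefore estimated to give 5600 nM in this assay, with a likely range from 2800 nM to 11000 nM.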

Compound 4, half-maximal inhibitory concentration: 5930 nM
Estimate against measurement, compound 4: 1.1-fold (0.02 log units) below; low and high end bracket the measured number.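

In this assay, putting 2-chlorophenyl in place of 4-chlorophenyl gives a 1.2-fold higher number from compound 3 to compound 4 (0.09 log units; within the scatter), and this agrees with the same change made on the other core: the same change on two cores in this assay, a 1.2-fold higher number (0.06 log units; within the scatter) from compound 2 to compound 1 and a 1.2-fold higher number (0.09 log units; within the scatter) from compound 3 to compound 4, 1.1-fold (0.02 log units) apart, within the scatter of two such steps

Putting thiophen-3-yl in place of thiophen-2-yl gives a 1.1-fold higher number from compound 1 to compound 4 (0.06 log units; within the scatter), and this change also agrees across the two cores: the same change on two cores in this assay, a 1.1-fold higher number (0.03 log units; within the scatter) from compound 2 to compound 3 and a 1.1-fold higher number (0.06 log units; within the scatter) from compound 1 to compound 4, 1.1-fold (0.02 log units) apart, within the scatter of two such steps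

For the compounds shown here, all of these steps lie within the scatter, which means the agreement shows only that both changes stay this small on these two cores; it does not show a real effect that carries from one core to another, and it says nothing about cores beyond these.

Still open, going by these compounds, is whether a larger step would appear with an amine or a carboxylic acid in place of the chlorine, or with a longer chain in place of the 4-hydroxyphenyl group. Also open, on these data alone, is whether the two changes would agree across these cores in any other kind of test.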